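Replacing a Fluorinated Amide with an Ester: Expected Tolerance

This account rests on a few compounds, and the source may have more. Where it says the series, first, only, none or still open, it means among the compounds named here.

Compound 1 `COc1ccc(C(=O)Nc2ccccc2)cc1NC(=O)C(C)Cl` gives 200 uM in an ADME assay on MDCK cells (Canis lupus familiaris) for cytotoxicity, read by cytopathic effect, with a stated time of 48 h; a higher number here means that more compound is tolerated, a lower number that less compound is tolerated.
Compound 2 `COc1ccc(C(=O)Nc2ccccc2)cc1NC(C)=O` reaches only a limit of the assay, > 703 uM.
Compound 3 `COc1ccc(C(=O)Nc2ccccc2)cc1NC(=O)C(C)F` likewise reaches only a limit of the assay, > 632 uM.

Compound 3 therefore sits at the upper edge of what this assay could report; of the three measured compounds, only compound 1 gives an actual number. Compound 4 `CCC(=O)Oc1cc(C(=O)Nc2ccccc2)ccc1OC` is built from compound 3 by a single change: propanoyloxy in place of ((1-fluoroethyl)carbonyl)amino on an aromatic carbon.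

For the measured compounds named here, two measured steps bear on this. The step of an at least 3.5-fold higher number from compound 1 to compound 2 (0.54 log units; beyond the scatter) and the step of an at least 3.1-fold higher number from compound 1 to compound 3 (0.49 log units; beyond the scatter) both show that removing the chlorine from the side chain moves the compound up to a limit. The step that the two limits leave unreadable from compound 2 to compound 3 cannot be sized because both ends are limits. Compound 4 carries neither chlorine nor fluorine, so its tolerance is expected to stay high, with a step of an at least 1.1-fold lower number from compound 3 to compound 4 (0.06 log units; that floor lies within the scatter) that is estimated to lie within the scatter. Compound 4 is thus expected to give about 550 uM, within 180 uM to 1000 uM, quite possibly again as a limit.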

Compound 4, half-maximal toxic concentration: 519 uM
The estimate for compound 4 lay 1.1-fold (0.03 log units) above the measured number, and the stated range covers the measured number.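

The new change shows that an ester on this aromatic carbon, with 0 hydrogen-bond donors in place of the amide's 1, can still be well tolerated in this assay: the record is a 2.6-fold higher number from compound 1 to compound 4 (0.41 log units; beyond the scatter). For the compounds shown here, compound 4 is also the first compound without chlorine to give an actual number rather than a limit, so the high end of this small set now has a readable value. Against the two compounds that reach limits, the steps are an at least 1.2-fold lower number from compound 3 to compound 4 (0.08 log units; that floor lies within the scatter) and an at least 1.3-fold lower number from compound 2 to compound 4 (0.13 log units; that floor lies within the scatter), and with both floors within the scatter, neither shows a real drop.

On these data alone, the true gap between compound 3 and compound 4 stays open, because compound 3 has only a limit: the limit of > 632 uM in this assay, at which 1 of the 4 values shown sits. As far as these compounds go, whether an amine or a longer chain such as butanoyloxy on this aromatic carbon would be tolerated equally well also remains open.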